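The source may report more compounds than this note shows. Statements on the series, on what has been measured and on what is new or still open speak of the compounds shown alone.

Going by the values given here, compound 2 `CC(=O)N1N=C2N(N=C(Cc3ccccc3)C(=O)N2N(C(C)=O)C(C)=O)C1c1ccccc1` is the weaker of the two measured members: in an assay on microsomes from liver for inhibition of cytochrome P450 1A1 (Rattus norvegicus), read by fluorescence, with a stated time of 10 min (on this read-out higher numbers stand for weaker inhibition and lower numbers for stronger inhibition), compound 2 gives 24.2 nM, the higher of the two numbers, whereas compound 1 `CC(=O)NN1C(=O)C(Cc2ccccc2)=NN2C1=NN(C(C)=O)C2(C)c1ccc(C)cc1` gives 6.62 nM, a gap beyond the scatter. Compound 3 `COc1ccc(CC2=NN3C(=NN(C(C)=O)C3c3ccccc3)N(N(C(C)=O)C(C)=O)C2=O)cc1` differs from compound 2 by methoxy in place of hydrogen on an aromatic carbon. Among the compounds with values here, no measured pair shows this change, so its effect is not known from the data. In this assay a step of a 1.2-fold lower number from compound 2 to compound 3 (0.08 log units; within the scatter) is expected, essentially within the scatter. Compound 3 is estimated at 20 nM, with a range of 8 nM to 50 nM.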

Compound 3, half-maximal inhibitory concentration: 86.7 nM
Beside the measured number, compound 3's estimate is 4.3-fold (0.64 log units) below it; the whole stated range lies below it.
By their numbers in this assay, from the lowest: compound 1; then compound 2; then compound 3.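

In this assay, going by these compounds alone, going from benzyl to 4-methoxybenzyl gives a 3.6-fold higher number from compound 2 to compound 3 (0.55 log units; beyond the scatter) and is the first reading of this position. The aromatic carbon of the benzyl ring is therefore not indifferent to substitution, and here methoxy goes with weaker inhibition. No available measurement accounts for the step.

Going by these compounds, this rests on a single pair, so it remains open whether the shift belongs to methoxy specifically or to any group at this carbon. Fluorine, a hydroxyl or a dimethylamino group there would help separate the two.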